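A few compounds are considered here, and "the series" means these few. Any claim that something is new, unique, unknown or untested is made for them only; others in the source may bear on it.

Measured so far:
- compound 1, `COc1cccc(-c2ccc(OC)c(S(=O)(=O)Nc3cccc(NCCNC(=O)c4ccccc4OC)c3)c2)c1`, 800 nM
- compound 2, `COc1ccccc1C(=O)NCCNc1cccc(NS(=O)(=O)c2cc(-c3cccc(C(=O)N(C)C)c3)ccc2OC)c1`, 50 nM
- compound 3, `COc1ccccc1C(=O)NCCNc1cccc(NS(=O)(=O)c2cc(-c3cccnc3)ccc2OC)c1`, 268 nM

All three were tested in an assay on CHO-K1 cells for agonist activity at Orexin receptor type 2 (Homo sapiens), read by a luciferase reporter; on this read-out lower numbers stand for an effect already at smaller amounts and higher numbers for an effect only at larger amounts of compound. On these numbers compound 2 stands lowest, meaning it acts at the smallest amount: a 5.4-fold higher number from compound 2 to compound 3 (0.73 log units; beyond the scatter), and a 16-fold lower number from compound 1 to compound 2 (1.20 log units; beyond the scatter).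

Compound 4, `COc1cccc(C(=O)NCCNc2cccc(NS(=O)(=O)c3cc(-c4cccc(C(=O)N(C)C)c4)ccc3OC)c2)c1`, is the next step from compound 2. The two contain the same atoms joined differently: 3-methoxyphenyl in place of 2-methoxyphenyl on a carbonyl carbon. In plain terms, the methoxy group on the benzamide ring at the far end of the shared core is moved from one position to another, while the rest of the molecule is unchanged.

Going by the values given here, none of the measured steps touches this part of the molecule. The steps seen so far all exchange the aryl group on the sulfonamide-bearing biphenyl portion: besides the two steps above, a 3.0-fold lower number from compound 1 to compound 3 (0.47 log units; beyond the scatter). Those steps show that this assay responds strongly to changes at that end, but they give no guidance on the benzamide end. Among the compounds with values here, with no step bearing on the change, the expectation for compound 4 is a step no larger than the scatter, here set as a slight rise, a 1.8-fold higher number from compound 2 to compound 4 (0.26 log units; within the scatter), with a wide range to reflect the uncertainty. Compound 4 is therefore estimated at 90 nM, between 25 nM and 400 nM.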

Compound 4, half-maximal effective concentration: 33 nM
Compound 4: the middle estimate sits 2.7-fold (0.44 log units) above what was measured, and the stated range covers the measured number.
By their numbers in this assay, from the lowest: compounds 4 and 2 (each within the scatter of the next); then compound 3; then compound 1.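

In this assay, 3-methoxyphenyl in place of 2-methoxyphenyl on a carbonyl carbon gives a 1.5-fold lower number from compound 2 to compound 4 (0.18 log units; within the scatter), so this pair cannot be told apart on this read-out. Going by these compounds alone, the earlier compounds differed only in another part of the molecule, where steps reached a 16-fold lower number from compound 1 to compound 2 (1.20 log units; beyond the scatter); this pair adds a first reading at the benzamide ring, and moving the methoxy group there produces no difference that stands clear of the scatter, at least with the 3-(dimethylcarbamoyl)phenyl group that compound 2 and compound 4 share. No measurement given here offers an explanation for this result.

The compounds shown do not say whether the methoxy group matters at all on this ring, since both carry one, and a plain phenyl, or a ring bearing an amine or a carboxylic acid instead, could give a quite different number. Going by these compounds, it also stays open whether the same move would give so small a step with the pyridin-3-yl of compound 3 or the 3-methoxyphenyl of compound 1 in place of that shared group.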